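Replacing a pyridine-bearing side chain with a phenyl one

A few compounds are considered here, and "the series" means these few. Any claim that something is new, unique, unknown or untested is made for them only; others in the source may bear on it.

Compound 1, `O[C@@H](c1ccccc1)[C@H]1CO[C@H](c2ccccc2)[C@@H](C/C=C/c2ccccn2)C1`: in a functional assay on HeLa cells (Homo sapiens) for cytotoxicity, read by WST assay, with a stated time of 48 h (on this read-out higher numbers stand for weaker inhibition and lower numbers for stronger inhibition), compound 1 gives 33800 nM.
Compound 2, `COc1ccc(/C=C/C[C@@H]2C[C@H]([C@H](O)c3ccc(OC)c(OC)c3)CO[C@H]2c2ccc(OC)c(OC)c2)cc1OC`: in this assay compound 2 gives 28700 nM.
Compound 3, `COc1ccc(/C=C/C[C@@H]2C[C@@H]([C@@H](OC)c3ccc(OC)c(OC)c3)CO[C@H]2c2ccc(OC)c(OC)c2)cc1OC`: in this assay compound 3 reaches only a limit of the assay, > 100000 nM.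

Going by the values given here, compound 1 and compound 2 are the only two with an actual number, and they sit within the usual scatter of each other, so neither can be called stronger or weaker. Compound 3 reports only a limit, as the limit of > 100000 nM in this assay, at which 1 of the 3 values shown sits, records. Compound 4, `O[C@@H](c1ccccc1)[C@H]1CO[C@H](c2ccccc2)[C@@H](C/C=C/c2ccccc2)C1`, has not yet been measured. It differs from compound 1 in one place: phenyl in place of pyridin-2-yl on a double-bonded chain carbon bound to a double-bonded chain carbon. Among the compounds with values here, no measured pair shows this particular change, so its effect is not known from the data. The step of a 1.4-fold lower number from compound 1 to compound 4 (0.13 log units; within the scatter) is expected to stay near the scatter, with at most a modest gain in potency. For compound 4 the estimate in this assay is 25000 nM, with a likely range from 8000 nM to 80000 nM.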

Compound 4, half-maximal inhibitory concentration: 6060 nM
Beside the measured number, compound 4's estimate is 4.1-fold (0.62 log units) above it; the whole stated range lies above it.
By their numbers in this assay, from the lowest: compound 4; then compounds 2 and 1 (each within the scatter of the next). At a limit, above all of these: compound 3.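

In this assay, phenyl in place of pyridin-2-yl on a double-bonded chain carbon bound to a double-bonded chain carbon gives a 5.6-fold lower number from compound 1 to compound 4 (0.75 log units; beyond the scatter), so this position responds to the change, and the nitrogen of the leaving ring is not required for the activity seen in compound 4. Going by these compounds alone, the earlier compounds offered no pair differing in one place, so this is the first single change that can be read. Nothing among the data shown accounts for the size of this step.

The compounds shown leave open whether another ring at this position, such as a thiophene, would hold or extend the step. They also leave open how an amine or a carboxylic acid on the phenyl ring, or a longer chain leading to it, would read out.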